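Aryl Substitution on the Shared Core and Cytotoxicity

The source may hold more compounds than are shown below. What is called first, only, known or untested is meant among the compounds shown, and "the series" means these compounds.

Measured compounds:
compound 1 `COc1ccccc1Oc1c(N)nc(-c2ccccc2)nc1Cl`, 3140 nM
compound 2 `COc1ccccc1Oc1c(N)nc(-c2ccc(Cl)cc2)nc1Cl`, 120 nM
compound 3 `COc1ccccc1Oc1c(N)nc(Cc2ccccc2)nc1OCCO`, 14000 nM

In a functional assay on SK-MEL-28 cells (Homo sapiens) for cytotoxicity, read by CCK-8 assay, with a stated time of 24 h (on this read-out higher numbers stand for weaker inhibition and lower numbers for stronger inhibition), compound 3 gives the highest number of the three; compound 1 sits nearest with a lower value, and compound 2 lies furthest below. Compound 4 `COc1ccccc1Oc1c(N)nc(-c2cccc(I)c2)nc1OCCO` differs from compound 3 in one place: 3-iodophenyl in place of benzyl on an aromatic carbon. Among the compounds with values here, the only step that bears on it is a 26-fold lower number from compound 1 to compound 2 (1.42 log units; beyond the scatter), which shows that a halogen on the aryl group changes this assay strongly in the direction of stronger inhibition. Within the data shown here, no step separates a benzyl from an aryl group directly, so that part of the change remains uncharted. Compound 4 is therefore expected to show a large downward step, an 18-fold lower number from compound 3 to compound 4 (1.24 log units; beyond the scatter), and its estimated value is 800 nM, within 150 nM to 4000 nM.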

Compound 4, half-maximal inhibitory concentration: 11200 nM
Beside the measured number, compound 4's estimate is 14-fold (1.15 log units) below it; measured number above the stated range.
By their numbers in this assay, from the lowest: compound 2; then compound 1; then compounds 4 and 3 (each within the scatter of the next).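

In this assay the exchange gives a 1.3-fold lower number from compound 3 to compound 4 (0.10 log units; within the scatter), so at this position, between two ring nitrogen atoms, 3-iodophenyl and benzyl cannot be told apart. Within the data shown here, the large change seen with chloro, a 26-fold lower number from compound 1 to compound 2 (1.42 log units; beyond the scatter), thus finds no counterpart in this step, which involves a different halogen and a different leaving group on a core with a 2-hydroxyethoxy group. No measurement at hand accounts for this result. The compounds shown leave open how an unsubstituted phenyl would read on this 2-hydroxyethoxy core, and whether an amine or a carboxylic acid on the aryl ring would move the number.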